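The source may report more compounds than this note shows. Statements on the series, on what has been measured and on what is new or still open speak of the compounds shown alone.

The four compounds share a peracetylated sugar linked through a triazole to the shared core, and differ in how that core is arranged or substituted. Compound 1 `CC(=O)OC[C@H]1O[C@@H](n2cc(Cn3cc(/C=C4/C(=O)Nc5ccccc54)c4ccccc43)nn2)[C@H](OC(C)=O)[C@@H](OC(C)=O)[C@@H]1OC(C)=O` gives in an ADME assay on NIH3T3 cells (Homo sapiens) for cytotoxicity, read by sulforhodamine B assay, with a stated time of 48 h (on this read-out higher numbers stand for weaker inhibition and lower numbers for stronger inhibition), only a limit of the assay, > 200000 nM. Compound 2 `CC(=O)OC[C@H]1O[C@@H](n2cc(CN3C(=O)/C(=C\c4ccccc4)c4ccccc43)nn2)[C@H](OC(C)=O)[C@@H](OC(C)=O)[C@@H]1OC(C)=O` has its double bond drawn Z, and in this assay compound 2 gives 22800 nM. Compound 3 `CC(=O)OC[C@H]1O[C@@H](n2cc(CN3C(=O)/C(=C/c4ccccc4)c4ccccc43)nn2)[C@H](OC(C)=O)[C@@H](OC(C)=O)[C@@H]1OC(C)=O` has the same atoms and bonds with the double bond drawn E. In this assay compound 3 gives only a limit of the assay, > 100000 nM. Among the compounds with values here, the single measured step, an at least 4.3-fold higher number from compound 2 to compound 3 (0.64 log units; beyond the scatter), therefore runs from a number to a limit, and it rests on the fact that compounds 2 and 3 differ only in the configuration as drawn alone. Compound 3 thus stands at a limit, with one further compound also at a limit and only compound 2 carrying a number.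

Compound 4 `CC(=O)OC[C@H]1O[C@@H](n2cc(CN3C(=O)/C(=C/c4ccc(N(C)C)cc4)c4ccccc43)nn2)[C@H](OC(C)=O)[C@@H](OC(C)=O)[C@@H]1OC(C)=O` is compound 3 with dimethylamino in place of hydrogen on an aromatic carbon. Within the data shown here, no measured step concerns a substituent on that ring; the one measured step concerns only the drawn configuration, so it gives no guide to this change. Compound 4 is therefore expected to stay near the limit of compound 3, a step of a number no higher from compound 3 to compound 4 (the limit leaves the size open) that is expected to be no more than scatter. Compound 4 is estimated at 100000 nM, between 30000 nM and 300000 nM.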

Compound 4, half-maximal inhibitory concentration: 12700 nM
Compound 4: middle estimate off by 7.9-fold (0.90 log units), on the high side; the measured number lies below the stated range.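

Before compound 4, the only measured step in this assay concerned the configuration as drawn, and nothing showed whether a substituent on the phenyl group mattered. The change from phenyl to 4-(dimethylamino)phenyl now shows that it does, with dimethylamino in place of hydrogen giving an at least 7.8-fold lower number from compound 3 to compound 4 (0.89 log units; beyond the scatter), so a double bond drawn E does not by itself hold a compound at a limit of the assay. The true size of this step remains open, because compound 3 stands at a limit and not at a number: the limit of > 100000 nM in this assay, at which 1 of the 4 values shown sits.

The compounds shown leave open whether dimethylamino at this place would lower the number to a similar extent in compound 2, whose double bond is drawn Z, since the two changes are not seen together in one pair. They also leave open whether the step belongs to dimethylamino in particular or would also appear with another group on that aromatic carbon, such as methoxy, a primary amine or a carboxylic acid.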